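Swapping anilino for chloromethyl on a carbonyl carbon

The source may report more compounds than this note shows. Statements on the series, on what has been measured and on what is new or still open speak of the compounds shown alone.

Values in a functional assay on MV4-11 cells (Homo sapiens) for cytotoxicity, read by MTT assay, with a stated time of 72 h (on this read-out lower numbers stand for stronger inhibition and higher numbers for weaker inhibition), so far:
Compound 1 `CCOC(=O)c1csc2nc(-c3ccc(NC(=O)CC)cc3)cn12` gives 9520 nM as a measured number
Compound 2 `CCOC(=O)c1csc2nc(-c3ccc(NS(=O)(=O)c4ccc(C)cc4)cc3)cn12` gives > 20000 nM as a limit
Compound 3 `CCOC(=O)c1csc2nc(-c3ccc(NC(=O)Nc4ccccc4)cc3)cn12` gives > 20000 nM as a limit

Compound 3 has only a limit and no number, and it stands at the limit of > 20000 nM in this assay, at which 2 of the 3 values shown sit, without an exact reading. Compound 4 `CCOC(=O)c1csc2nc(-c3ccc(NC(=O)CCl)cc3)cn12` carries chloromethyl in place of anilino on a carbonyl carbon is the counted difference. The closest measured change is an at least 2.1-fold higher number from compound 1 to compound 3 (0.32 log units; beyond the scatter) with anilino in place of ethyl on a carbonyl carbon, a step of at least modest size. Compound 4 loses that anilino, so its number is expected to return towards compound 1 at 9520 nM in this assay. The estimated change is an at least 3.3-fold lower number from compound 3 to compound 4 (0.52 log units; beyond the scatter) towards a lower number. The estimate for compound 4 is 6000 nM (expected range 1500 nM to 18000 nM).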

Compound 4, half-maximal inhibitory concentration: 9070 nM
Beside the measured number, compound 4's estimate is 1.5-fold (0.18 log units) below it, and the stated range covers the measured number.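

Chloromethyl in place of anilino on a carbonyl carbon brings back a readable number in this assay, with an at least 2.2-fold lower number from compound 3 to compound 4 (0.34 log units; beyond the scatter), and (chloromethyl)carbonyl in place of (4-methylphenyl)sulfonyl does the same, with an at least 2.2-fold lower number from compound 2 to compound 4 (0.34 log units; beyond the scatter). Both steps start from a limit, not an exact number: the limit of > 20000 nM in this assay, at which 2 of the 4 values shown sit. Chloro in place of methyl on a saturated chain carbon bound to a carbonyl carbon leaves the reading unchanged, with a 1.0-fold lower number from compound 1 to compound 4 (0.02 log units; within the scatter).

The step between the two limits cannot be read. Going by these compounds, whether a longer chain or an amine at this place would lower the number further stays open.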